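Ethoxy for propoxy at the aryl oxygen: cytotoxicity notes

The source may hold more compounds than are shown below. What is called first, only, known or untested is meant among the compounds shown, and "the series" means these compounds.

Measured compounds:
Compound 1, `CCCCSc1nc(N)nc2c1ncn2/C=C1/CC1(CO)CO`, in an ADME assay on CCRF-HSB-2 cells (Homo sapiens) for cytotoxicity, with a stated time of 7 days; a higher number here means that more compound is tolerated, a lower number that less compound is tolerated: 89000 nM.
Compound 2, `Nc1nc(NC2CC2)c2ncn(/C=C3/CC3(CO)CO)c2n1`: > 20000 nM, a limit of the assay.
Compound 3, `CCCOc1nc(N)nc2c1ncn2/C=C1/CC1(CO)CO`: > 20000 nM, a limit of the assay.

Compound 3 stands only at a limit in this assay; no number is known for it. Two of the three values shown sit at that limit, as noted in the limit of > 20000 nM in this assay, at which 2 of the 3 values shown sit. Compound 4, `CCOc1nc(N)nc2c1ncn2/C=C1/CC1(CO)CO`, is yet to be measured. It differs from compound 3 by hydrogen in place of methyl on a saturated chain carbon, two bonds along the chain from an oxygen on an aromatic ring.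

Three measured steps exist. a step that the limit leaves unreadable from compound 1 to compound 2. a step that the limit leaves unreadable from compound 1 to compound 3. a step that the two limits leave unreadable from compound 2 to compound 3. None of them gives a readable size, so none tells how exchanging one chain for another at the oxygen on the aromatic ring moves the readout. Only the two steps ending at compound 3 touch the propoxy group, and both are unreadable. Nothing measured therefore points to any step in this assay beyond the scatter in either direction, and the most likely outcome is again a limit. Relative to compound 3, compound 4 is expected to show a step that the limit leaves unreadable from compound 3 to compound 4, that is, no change beyond the scatter. The estimate for compound 4 is 40000 nM, with a range from 15000 nM to 120000 nM.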

Compound 4, half-maximal cytotoxic concentration: > 20000 nM
Compound 4 ended at the assay's limit; the forecaster's own chance of this, stated with the estimate: 70%; the middle value lies beyond the limit too.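

In this assay compound 4 gives > 20000 nM, a limit and not a number. Among the compounds shown here, no step to compound 4 from compound 1, compound 2 or compound 3 can be read: the limit of > 20000 nM in this assay, at which 3 of the 4 values shown sit. The compounds shown leave open where the true values of compound 2, compound 3 and compound 4 lie, and whether propoxy to ethoxy moves the read-out at all.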